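A few compounds are considered here, and "the series" means these few. Any claim that something is new, unique, unknown or untested is made for them only; others in the source may bear on it.

Measured compounds in this set: compound 1 `CN(C(=O)NC(=O)c1cccc(C(F)(F)F)c1)c1nc(C(F)(F)F)c(C(=O)N/N=C/c2cccc(C(F)(F)F)c2)s1`, compound 2 `CN(C(=O)NC(=O)c1ccccc1F)c1nc(C(F)(F)F)c(C(=O)N/N=C/c2ccc(C(F)(F)F)cc2)s1`, compound 3 `CN(C(=O)NC(=O)c1ccccc1F)c1nc(C(F)(F)F)c(C(=O)N/N=C/c2ccccc2C(F)(F)F)s1`.

In a functional assay on HepG2 cells (Homo sapiens) for inhibition, read by MTT assay, with a stated time of 72 h (a higher number here means a weaker inhibitor, a lower number a stronger inhibitor), compound 1 gives 5.79 ug/mL, compound 2 gives 4.56 ug/mL, and compound 3 gives 5.39 ug/mL. Compound 3 thus sits second highest of the three numbers, but all three lie within the scatter of one another, so no order can be read among them. Within the data shown here, the one measured step, a 1.2-fold higher number from compound 2 to compound 3 (0.07 log units; within the scatter), changes the aryl on the carbon with a double bond to nitrogen and does not touch the carbonyl side.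

Compound 4 `CN(C(=O)NC(=O)c1cccc(C(F)(F)F)c1)c1nc(C(F)(F)F)c(C(=O)N/N=C/c2ccccc2C(F)(F)F)s1` differs from compound 3 by 3-(trifluoromethyl)phenyl in place of 2-fluorophenyl on a carbonyl carbon. Among the measured compounds shown here, no measured step bears directly on this change; the 3-(trifluoromethyl)phenyl on the carbonyl is present in compound 1, whose number is within the scatter of compound 3. For the measured compounds named here, with every number so far in one narrow band, compound 4 is expected to show a 1.0-fold higher number from compound 3 to compound 4 (0.01 log units; within the scatter), that is, no step beyond the scatter. For compound 4 the estimate in this assay is 5.5 ug/mL, in the range 3 ug/mL to 10 ug/mL.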

Compound 4, half-maximal inhibitory concentration: 10.4 ug/mL
For compound 4 the middle estimate is 1.9-fold (0.28 log units) below the measured one; measured number above the stated range.
By their numbers in this assay, from the lowest: compounds 2, 3, 1 and 4 (each within the scatter of the next, the first and the last beyond it).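

In this assay, the carbonyl side now has its first direct step: 3-(trifluoromethyl)phenyl in place of 2-fluorophenyl on a carbonyl carbon gives a 1.9-fold higher number from compound 3 to compound 4 (0.29 log units; within the scatter). With that carbonyl group held constant, a change of the aryl on the carbon with a double bond to nitrogen gives a 1.8-fold higher number from compound 1 to compound 4 (0.25 log units; within the scatter), so neither single change reaching compound 4 goes beyond the scatter. No supporting evidence bears on these steps.

Open, going by these compounds, is how a carboxylic acid or an amine on the carbonyl-bound phenyl, or a longer chain in place of that phenyl, would read in this assay.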